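The source may report more compounds than this note shows. Statements on the series, on what has been measured and on what is new or still open speak of the compounds shown alone.

Compound 1 `O=C(O)CCCO/N=c1/ccn([C@@H]2O[C@H](COP(=O)(O)OP(=O)(O)OP(=O)(O)O)[C@@H](O)[C@H]2O)c(=O)[nH]1` — in a functional assay on 1321-N1 cells for agonist activity at P2Y purinoceptor 6 (Homo sapiens), read by scintillation counting and inositol phosphate accumulation (a higher number here means that more compound is needed for the effect, a lower number that less compound is needed), compound 1 gives 697 nM.
Compound 2 `O=c1[nH]/c(=N\OCCCCc2ccccc2)ccn1[C@@H]1O[C@H](COP(=O)(O)OP(=O)(O)OP(=O)(O)O)[C@@H](O)[C@H]1O` — compound 2 gives 251 nM.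
Compound 3 `O=c1[nH]/c(=N\OCCCc2cccc(F)c2)ccn1[C@@H]1O[C@H](COP(=O)(O)OP(=O)(O)OP(=O)(O)O)[C@@H](O)[C@H]1O` — compound 3 gives 539 nM.

Among these three numbers compound 3 holds the second highest place. Its nearest neighbour is compound 1, and the step of a 1.3-fold lower number from compound 1 to compound 3 (0.11 log units; within the scatter) keeps the two within the scatter, so no order can be read between them; compound 2, on the other hand, stands apart, since a 2.1-fold higher number from compound 2 to compound 3 (0.33 log units; beyond the scatter) lies beyond the scatter, as does a 2.8-fold lower number from compound 1 to compound 2 (0.44 log units; beyond the scatter).

Compound 4 `COc1ccc(CCCO/N=c2/ccn([C@@H]3O[C@H](COP(=O)(O)OP(=O)(O)OP(=O)(O)O)[C@@H](O)[C@H]3O)c(=O)[nH]2)cc1` is the next member. Its change from compound 3 reads (4-methoxyphenyl in place of 3-fluorophenyl on a saturated chain carbon, three bonds along the chain from an oxygen). The step that bears on it most directly is a 2.1-fold higher number from compound 2 to compound 3 (0.33 log units; beyond the scatter), which swapped one aryl end for another and moved the number only modestly; a 1.3-fold lower number from compound 1 to compound 3 (0.11 log units; within the scatter) shows an aryl end replacing a carboxy end with no change beyond the scatter. An aryl-for-aryl exchange of this kind is therefore expected to give at most a modest shift, if any, in this assay, with no clear direction. For compound 4 the expected step is a 1.2-fold lower number from compound 3 to compound 4 (0.08 log units; within the scatter). Compound 4 is estimated at 450 nM, within the range 200 nM to 1000 nM.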

Compound 4, half-maximal effective concentration: 277 nM
Compound 4: middle estimate off by 1.6-fold (0.21 log units), on the high side; the range from low to high includes it.
By their numbers in this assay, from the lowest: compounds 2, 4, 3 and 1 (each within the scatter of the next, the first and the last beyond it).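

In this assay, replacing 3-fluorophenyl with 4-methoxyphenyl gives a 1.9-fold lower number from compound 3 to compound 4 (0.29 log units; within the scatter), so this aryl exchange on the propyl chain establishes no order between the two compounds. Even so, a 2.5-fold lower number from compound 1 to compound 4 (0.40 log units; beyond the scatter) separates the 4-methoxyphenyl end from the carboxy end, which the 3-fluorophenyl end did not do, while a 1.1-fold higher number from compound 2 to compound 4 (0.04 log units; within the scatter) leaves compound 4 inseparable from compound 2, so the aryl ends do not all stand alike against the carboxy end. No evidence is available that accounts for these steps.

The 3-fluorophenyl and 4-methoxyphenyl names differ in both the substituent and its number on the ring, so the compounds shown cannot separate those two changes. As far as these compounds go, it also remains open how an amine at the chain end, or a longer chain carrying the 4-methoxyphenyl group, would behave.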